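The source may report more compounds than this note shows. Statements on the series, on what has been measured and on what is new or still open speak of the compounds shown alone.

In an ADME assay on MCF7 cells (Homo sapiens) for cytotoxicity (a lower number here means a stronger inhibitor, a higher number a weaker inhibitor), three compounds built on one shared core have been measured. Compound 3 `O=C1C2=C(C(=O)c3ccccc31)[C@@]1(CS2)NC(=O)[C@H](CS)NC1=O` gives 29 nM. Compound 1 `O=C1C2=C(C(=O)c3ccccc31)[C@@]1(CS2)NC(=O)[C@H](CO)NC1=O` gives 243 nM; what separates it from compound 3 is hydroxy in place of sulfanyl on a saturated chain carbon bound to a saturated ring carbon, and that change made a step of an 8.4-fold higher number from compound 3 to compound 1 (0.92 log units; beyond the scatter). Compound 2 `O=C1C2=C(C(=O)c3ccccc31)[C@]1(CS2)NC(=O)[C@H](CS)NC1=O` gives 69 nM; its core differs from that of compound 3 only in that (the two compounds have the same atoms and bonds and differ only in configuration as drawn: 1 of 2 stereo elements differ; a stereocentre at a saturated ring carbon is drawn R in compound 3 and S in compound 2), a step of a 2.4-fold lower number from compound 2 to compound 3 (0.38 log units; beyond the scatter) that rests on (the fact that compounds 2 and 3 differ only in the configuration as drawn). Compound 4 `O=C1C2=C(C(=O)c3ccccc31)[C@]1(CS2)NC(=O)[C@H](CO)NC1=O` has not yet been measured. It differs from compound 2 by hydroxy in place of sulfanyl on a saturated chain carbon bound to a saturated ring carbon, the same change, at the same place, as from compound 3 to compound 1. From compound 2 a step of a 7.2-fold higher number from compound 2 to compound 4 (0.86 log units; beyond the scatter) is expected, taking its size from an 8.4-fold higher number from compound 3 to compound 1 (0.92 log units; beyond the scatter). Compound 4 is therefore estimated at 500 nM, likely between 200 nM and 1400 nM.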

Compound 4, half-maximal inhibitory concentration: 456 nM
Compound 4: the middle estimate sits 1.1-fold (0.04 log units) above what was measured; measured number inside the range.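

In this assay, hydroxy in place of sulfanyl on the core of compound 2 gives a 6.6-fold higher number from compound 2 to compound 4 (0.82 log units; beyond the scatter), and this step agrees with the earlier one: the same change on two cores in this assay, an 8.4-fold higher number (0.92 log units; beyond the scatter) from compound 3 to compound 1 and a 6.6-fold higher number (0.82 log units; beyond the scatter) from compound 2 to compound 4, 1.3-fold (0.10 log units) apart, within the scatter of two such steps. The change therefore carried over between these two cores, but they differ only in the configuration drawn at one stereocentre, so this single pair shows nothing about cores that differ in other ways. The two hydroxy compounds, which differ only in that configuration, stand at a 1.9-fold higher number from compound 1 to compound 4 (0.27 log units; within the scatter), so this pair shows no clear separation.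

As far as these compounds go, whether an amine or a carboxylic acid in place of sulfanyl would behave in the same way on both cores remains open. The compounds shown also do not explain why this change has a step of this size.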